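Vero cell tolerance in a cyclopentylamino series

A few compounds are considered here, and "the series" means these few. Any claim that something is new, unique, unknown or untested is made for them only; others in the source may bear on it.

Measured so far:
- compound 1 `Fc1ccc(-c2nn3c(NC4CCCC4)cccc3c2-c2ccnc(NC3CCCC3)n2)cc1`: > 160000 nM
- compound 2 `COc1ccc(-c2nn3c(NC4CCCC4)cccc3c2-c2ccnc(NC3CCCC3)n2)cc1`: > 100000 nM

Both values are limits of an ADME assay on Vero cells (Chlorocebus sabaeus) for cytotoxicity (a higher number here means that more compound is tolerated, a lower number that less compound is tolerated), rather than numbers. In this assay compound 1 gives > 160000 nM, a limit of the assay. Compound 2 gives > 100000 nM, likewise a limit. For the measured compounds named here, the one measured step, a step that the two limits leave unreadable from compound 1 to compound 2, is therefore unreadable: the two limits the limit of > 100000 nM in this assay, at which 1 of the 2 values shown sits, and the limit of > 160000 nM in this assay, at which 1 of the 2 values shown sits, leave no room to read its size or direction. Compound 1 thus stands only at a limit, with no number of its own.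

Compound 3 `Fc1ccc(-c2nn3c(NC4CCCC4)cc(NC4CCCC4)cc3c2-c2ccnc(NC3CCCC3)n2)cc1` differs from compound 1 by cyclopentylamino in place of hydrogen on an aromatic carbon. Going by the values given here, no measured step covers this change; the only step at hand, from compound 1 to compound 2, concerns a different position and is itself unreadable. Among the compounds with values here, nothing among the measured compounds points toward a drop in tolerance, and both sit at the top of the assay's range. Compound 3 is therefore expected to remain well tolerated, with the step of an at least 1.6-fold lower number from compound 1 to compound 3 (0.20 log units; that floor lies within the scatter) estimated as none beyond the scatter. The estimate for compound 3 in this assay is 100000 nM, within 30000 nM to 200000 nM.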

Compound 3, half-maximal cytotoxic concentration: > 40000 nM
Compound 3 was reported as a limit (the forecaster's own chance of this, stated with the estimate: 60%); the middle value is on the limit's open side.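

In this assay compound 3 gives > 40000 nM, which is a limit and not a number. Compound 1 also stands only at a limit, so no step can be read between compound 1 and compound 3. The compounds shown leave open how large any difference in tolerance is among compound 1, compound 2 and compound 3, as none has a number of its own.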